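Acetyl removal from compound 1: expected step

The compounds below may be only part of what the source reports. "The series", "measured", "known", "first", "only" and "open" are said of these compounds alone.

Compound 1 `COc1cc(/C=C/c2cn(C(C)=O)c3ccccc23)cc(OC)c1OC` has no exact figure in a functional assay on HeLa cells (Homo sapiens) for inhibition; on this read-out higher numbers stand for weaker inhibition and lower numbers for stronger inhibition: compound 1 reads > 5000 nM, which is a limit and not a number. Compound 2 `COc1cc(/C=C\c2cn(C(C)=O)c3ccccc23)cc(OC)c1OC` reads 2850 nM in this assay. Within the data shown here, the only measured step, an at least 1.7-fold lower number from compound 1 to compound 2 (0.24 log units; that floor lies within the scatter), concerns (the fact that compounds 1 and 2 differ only in the configuration as drawn), so it does not touch the acetyl.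

Compound 3 `COc1cc(/C=C/c2c[nH]c3ccccc23)cc(OC)c1OC` keeps the configuration of compound 1 and changes in one place: hydrogen in place of acetyl on an aromatic nitrogen. Among the measured compounds shown here, no measured step covers this change, so neither its size nor its direction can be derived from the data. The expectation therefore stays close to compound 1, whose > 5000 nM is again only a limit. The expected step is a number no higher from compound 1 to compound 3 (the limit leaves the size open), with none beyond the scatter anticipated. The estimated value for compound 3 is 5000 nM, with an expected range of 1500 nM to 15000 nM.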

Compound 3, half-maximal inhibitory concentration: 3230 nM
Beside the measured number, compound 3's estimate is 1.5-fold (0.19 log units) above it, within the range that was stated.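

Hydrogen in place of acetyl on the aromatic nitrogen gives, in this assay, an at least 1.5-fold lower number from compound 1 to compound 3 (0.18 log units; that floor lies within the scatter), and this is the only reading so far on this position. Compound 3 has an exact value, so a measurable reading with the E double bond does not require the acetyl on this nitrogen. The floor of the step does not show that the acetyl weakens inhibition, and the step gives no firm direction.

The true size of the step stays open because one of its two ends is only a limit: the limit of > 5000 nM in this assay, at which 1 of the 3 values shown sits.

Also open, as far as these compounds go, is how a methyl, a longer acyl chain or an amine-bearing chain on this nitrogen would read in this assay, and whether hydrogen on this nitrogen would read the same with the Z double bond of compound 2.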